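The compounds below may be only part of what the source reports. "The series", "measured", "known", "first", "only" and "open" are said of these compounds alone.

Of the compounds shown here, three built around the same core have been measured so far. Compound 1 `O=C(CCC1=CCN(CCCc2ccc(Br)cc2)C1=O)NO` carries a three-carbon chain to a bromophenyl group; in a functional assay on PC-3 cells (Homo sapiens) for inhibition, read by sulforhodamine B assay (on this read-out lower numbers stand for stronger inhibition of growth and higher numbers for weaker inhibition of growth), compound 1 gives 3480 nM. Compound 2 `Cc1ccc(CCCCN2CC=C(CCC(=O)NO)C2=O)cc1` carries a four-carbon chain to a methylphenyl group, and in this assay compound 2 gives 6090 nM. Compound 3 `O=C(CCC1=CCN(Cc2cccc(Br)c2)C1=O)NO` has a one-carbon link to a bromophenyl group, and in this assay compound 3 gives 4620 nM. Of the three numbers, compound 3 gives the second highest, but its gap to compound 2, the nearest, and to compound 1, the furthest, both fall within the usual scatter of repeated measurements, so the three compounds cannot be told apart on these data.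

Compound 4 `N#Cc1cccc(CN2CC=C(CCC(=O)NO)C2=O)c1` is not yet measured. It differs from compound 3 in one place: cyano in place of bromo on an aromatic carbon. Among the measured compounds shown here, no pair of measured compounds shows this exchange, so there is no measured step to lean on. Since the three known values sit so close together, the exchange is expected to give a change of a 1.2-fold higher number from compound 3 to compound 4 (0.08 log units; within the scatter), that is, nothing beyond the scatter, perhaps a slightly higher number. Compound 4 is therefore estimated at 5500 nM, within a range from 2500 nM to 12000 nM.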

Compound 4, concentration for 50% growth inhibition: 7920 nM
Beside the measured number, compound 4's estimate is 1.4-fold (0.16 log units) below it, within the range that was stated.
By their numbers in this assay, from the lowest: compounds 1, 3, 2 and 4 (each within the scatter of the next, the first and the last beyond it).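

Among the compounds shown here, this is the first measured exchange on the aromatic ring, at the carbon meta to a large group, and in this assay cyano in place of bromo gives a 1.7-fold higher number from compound 3 to compound 4 (0.23 log units; within the scatter), a step that stays inside the usual scatter of repeated measurements. For the compounds shown here, a single bromine atom can therefore give way to a cyano group, with its two heavy atoms, its triple bond and its one hydrogen-bond acceptor, and the growth-inhibition read-out shows no change that can be told from noise at this position, which the earlier compounds, with no measured step among them, could not show. No measurement of any property of these two groups is available to bear on this result, so the step can be stated but not explained.

One pair cannot show whether the same exchange would behave alike on the longer three-carbon chain of compound 1, where the bromophenyl group sits farther from the shared core. It also leaves open what groups of a quite different kind, such as an amine, a carboxylic acid or a methoxy group, would do on this same aromatic carbon.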